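Swapping a chlorophenyl for a morpholine-bearing group on sulfur

The source may hold more compounds than are shown below. What is called first, only, known or untested is meant among the compounds shown, and "the series" means these compounds.

Of the compounds shown here, three built on a shared core have been tested in a functional assay on SK-MEL-28 cells (Homo sapiens) for inhibition, read by MTT assay, with a stated time of 72 h; on this read-out lower numbers stand for stronger inhibition of growth and higher numbers for weaker inhibition of growth. Compound 1 `Clc1ccc(Sc2c(-c3ccc(Br)cc3)[nH]c3ccccc23)cc1` gives 26000 nM. Compound 2 `CCN(CC)C(=S)Sc1c(-c2ccccc2)[nH]c2ccc(Br)cc12` gives 28000 nM, and compound 3 `Clc1ccc(Sc2c(-c3ccc(Cl)cc3)[nH]c3ccccc23)cc1` gives 34000 nM. Compound 1 has the lowest of these three numbers, but its gaps to compound 2 and to compound 3 both lie within the scatter, so no order among them can be claimed. Among the measured compounds shown here, the only single-point step measured, a 1.3-fold higher number from compound 1 to compound 3 (0.12 log units; within the scatter), is also within the scatter.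

Compound 4 `S=C(Sc1c(-c2ccc(Br)cc2)[nH]c2ccccc12)N1CCOCC1` is not yet measured. It differs from compound 1 as follows: a group of 8 heavy atoms (5 carbon, 1 nitrogen, 1 oxygen, 1 sulfur; one six-membered non-aromatic ring with 2 hetero atoms) in place of a group of 7 heavy atoms (6 carbon, 1 chlorine; one six-membered aromatic ring of carbon only), on a sulfur. For the measured compounds named here, no measured step exchanges one group for another on that sulfur; compound 2 carries a different sulfur-bound group but also differs from compound 4 elsewhere, so only its value can be noted. Going by the values given here, with the one measured step flat, the expected step of a 1.0-fold higher number from compound 1 to compound 4 (0.02 log units; within the scatter) is none beyond the scatter. Compound 4 is therefore estimated at 27000 nM, within 11000 nM to 65000 nM.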

Compound 4, concentration for 50% growth inhibition: 35000 nM
Compound 4: the middle estimate sits 1.3-fold (0.11 log units) below what was measured; the range from low to high includes it.
By their numbers in this assay, from the lowest: compounds 1, 2, 3 and 4 (each within the scatter of the next).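

In this assay, the exchange on the sulfur gives a 1.3-fold higher number from compound 1 to compound 4 (0.13 log units; within the scatter). Among the compounds shown here, this is the first measured exchange of one group for another at this place, and it joins two very different groups: the 4-chlorophenyl, with its aromatic ring of carbon only and no hydrogen-bond acceptors, and a group with a six-membered non-aromatic ring, a double bond outside aromatic rings and 2 hydrogen-bond acceptors. Even so, the step stays within the scatter, and no measurement at hand offers an explanation for this result.

As far as these compounds go, whether any group on this sulfur can move the number beyond the scatter remains open. A small methyl or a longer chain ending in an amine or a carboxylic acid could test this.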